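The source may report more compounds than this note shows. Statements on the series, on what has been measured and on what is new or still open speak of the compounds shown alone.

For the measured compounds named here, in a functional assay on the whole organism for agonist activity, with Mus musculus as the target (on this read-out lower numbers stand for an effect already at smaller amounts and higher numbers for an effect only at larger amounts of compound), compound 2 `CC(=O)N(C)CC#CCn1cncc1C` gives 5.4 mg/kg, the only true number in this small set. Compound 1 `CC(=O)N(C)C(C)C#CCn1cncc1C` reads > 100 mg/kg, which is a limit and not a number. Compound 3 `COC(=O)NCC#CCn1cncc1C` reads > 100 mg/kg, which is also a limit.

Compound 4 `Cc1cncn1CC#CCN(C)C(=O)N(C)C` has not yet been measured. It differs from compound 2 in one place: dimethylamino in place of methyl on a carbonyl carbon. In words, dimethylamino stands in place of methyl on a carbonyl carbon, so acetyl becomes dimethylcarbamoyl.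

Two measured steps offer guidance. The closer one put (methoxycarbonyl)amino in place of acetyl(methyl)amino, the group that also changes here, and gave an at least 18-fold higher number from compound 2 to compound 3 (1.26 log units; beyond the scatter). The other, hydrogen in place of methyl on a saturated chain carbon, gave an at least 18-fold lower number from compound 1 to compound 2 (1.26 log units; beyond the scatter), but it lies in a different part of the molecule. On these data alone, both are large, and both touch (the limit of > 100 mg/kg in this assay, at which 2 of the 3 values shown sit), so their true sizes remain open.

With an at least 18-fold higher number from compound 2 to compound 3 (1.26 log units; beyond the scatter) as the closest guide, a move toward a higher number in this assay is expected, though probably a smaller one than that step, and a reading at the limit remains possible. The estimated change is a 5.6-fold higher number from compound 2 to compound 4 (0.74 log units; beyond the scatter). For compound 4 the expected value is 30 mg/kg, with an estimated range from 6 mg/kg to 150 mg/kg.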

Compound 4, dose for half-maximal effect: 45.2 mg/kg
Compound 4: the middle estimate sits 1.5-fold (0.18 log units) below what was measured; low and high end bracket the measured number.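

In this assay, the exchange of acetyl for dimethylcarbamoyl, with dimethylamino in place of methyl on a carbonyl carbon, gives an 8.4-fold higher number from compound 2 to compound 4 (0.92 log units; beyond the scatter). For the compounds shown here, this is the first step in the set with a true number at both ends, so its full size can be read directly, and the change at this carbonyl carbon raises the dose needed without carrying compound 4 to the limit of the assay. The two earlier steps could not give such a size, and they fix only a minimum because each of them has one end at a limit: the limit of > 100 mg/kg in this assay, at which 2 of the 4 values shown sit.

On these data alone, whether the higher number goes with the nitrogen itself or with the two methyl groups it carries stays open, since a plain amino group or an ethyl group on the same carbonyl carbon would be needed to tell these apart. Also open, as far as these compounds go, is how the effect would respond to a larger group at this carbon, such as a pyrrolidine ring bound through its nitrogen, which could show whether the trend continues or stops.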